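A few compounds are considered here, and "the series" means these few. Any claim that something is new, unique, unknown or untested is made for them only; others in the source may bear on it.

Compound 1 `COc1cc(N)c(Cl)cc1C(=O)NC1CCN(CC2CCN(C(=O)CCCN)CC2)CC1`: 3.99 nM
Compound 2 `COc1cc(N)c(Cl)cc1C(=O)NCC(O)CN1CCC(CN2CCC(N)CC2)CC1`: 40.6 nM

Both numbers come from an assay on striatum for inhibition of 5-hydroxytryptamine receptor 4 (Cavia porcellus), read by radioligand binding; on this read-out lower numbers stand for stronger inhibition and higher numbers for weaker inhibition. Compound 1 carries the lowest of the two; compound 2 sits well above it, a gap beyond the scatter. Compound 3 `CCCC(N)C(=O)N1CCC(CN2CCC(NC(=O)c3cc(Cl)c(N)cc3OC)CC2)CC1` has not been measured in this assay. It differs from compound 1 by 1-aminobutyl in place of 3-aminopropyl on a carbonyl carbon. Within the data shown here, no measured pair shows this kind of change, so the size of the step is open. The step of a 1.5-fold higher number from compound 1 to compound 3 (0.18 log units; within the scatter) is expected to be small, within the scatter or a little beyond it, in the weaker direction. For compound 3 the expected value is 6 nM, with a range from 2 nM to 20 nM.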

Compound 3, half-maximal inhibitory concentration: 2.57 nM
Compound 3: the middle estimate sits 2.3-fold (0.37 log units) above what was measured, within the range that was stated.
By their numbers in this assay, from the lowest: compounds 3 and 1 (each within the scatter of the next); then compound 2.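

In this assay, the series shows a 1.6-fold lower number from compound 1 to compound 3 (0.19 log units; within the scatter) when 1-aminobutyl stands in place of 3-aminopropyl on a carbonyl carbon. This first single-place pair therefore shows that the two amine-bearing chains cannot be told apart at this position. No supporting data bear on why they read alike.

Going by these compounds, whether this position would accept a carboxylic acid, a dimethylamino group or a longer amine-bearing chain remains open. One pair also leaves open whether the same change would read alike on another core.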